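Silyl-ether cyclopentenones: aryl swap toward a methoxydimethylphenyl

A few compounds are considered here, and "the series" means these few. Any claim that something is new, unique, unknown or untested is made for them only; others in the source may bear on it.

Measured so far:
compound 1 `COc1ccc(C2=C(c3cc(OC)c(OC)c(OC)c3)C(=O)CC2O[SiH2]C(C)(C)C)cc1OC` — > 100 ug/mL
compound 2 `COc1ccc(OC)c(C2=C(c3cc(OC)c(OC)c(OC)c3)C(=O)CC2O[SiH2]C(C)(C)C)c1` — 17 ug/mL

In an ADME assay on PA-1 cells (Homo sapiens) for cytotoxicity, read by MTT assay, with a stated time of 72 h (on this read-out higher numbers stand for weaker inhibition and lower numbers for stronger inhibition), compound 1 gives only a limit, > 100 ug/mL, not a number. Compound 2 gives the only plain number shown, 17 ug/mL. Its standing therefore rests on a single comparison with compound 1. Within the data shown here, the one measured step, an at least 5.8-fold lower number from compound 1 to compound 2 (0.76 log units; beyond the scatter), bears on the present question only loosely, since it concerns the limit of > 100 ug/mL in this assay, at which 1 of the 2 values shown sits, and therefore gives a lower bound on its size rather than a size.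

Compound 3 `COc1cc(C2=C(c3cc(C)c(OC)c(C)c3)C(O[SiH2]C(C)(C)C)CC2=O)cc(OC)c1OC` carries 4-methoxy-3,5-dimethylphenyl in place of 2,5-dimethoxyphenyl on a double-bonded ring carbon. Among the measured compounds shown here, no measured step covers this particular change; the single measured step shows that swapping the aryl on the double-bonded ring carbon can move the number beyond the scatter, in either direction as far as the data tell.

Compound 3 is therefore expected near 40 ug/mL, between 10 ug/mL and 100 ug/mL. The expected step, a 2.4-fold higher number from compound 2 to compound 3 (0.37 log units; beyond the scatter), is a weakening that may or may not clear the scatter.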

Compound 3, half-maximal inhibitory concentration: 32 ug/mL
The estimate for compound 3 lay 1.3-fold (0.10 log units) above the measured number; the range from low to high includes it.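

In this assay, the change from 2,5-dimethoxyphenyl to 4-methoxy-3,5-dimethylphenyl on the double-bonded ring carbon gives a 1.9-fold higher number from compound 2 to compound 3 (0.27 log units; within the scatter), so these two aryl groups are not told apart here, although the entering group has 1 hydrogen-bond acceptor and the leaving group 2. Set against the 3,4-dimethoxyphenyl group, the new aryl group gives an at least 3.1-fold lower number from compound 1 to compound 3 (0.49 log units; beyond the scatter), making it the second aryl group at this position to separate from compound 1. That step is a bound and not a size, since compound 1 gives a limit rather than a number: the limit of > 100 ug/mL in this assay, at which 1 of the 3 values shown sits.

Still open, on these data alone, is whether any methoxy group on this aryl ring is needed, which an aryl ring bearing an amine or a carboxylic acid instead would test. The contribution of the silyl ether also remains open, as all compounds shown carry it.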